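The source may hold more compounds than are shown below. What is called first, only, known or untested is meant among the compounds shown, and "the series" means these compounds.

Measured compounds:
- compound 1, `CCC[C@H](O)Nc1nc(Nc2cccc(-c3ncccn3)c2)c2ncn(C(C)C)c2n1`: 730 nM
- compound 2, `CC(C)C[C@H](O)Nc1nc(Nc2cccc(-c3ncccn3)c2)c2ncn(C(C)C)c2n1`: "not determined" (no result reported)
- compound 3, `CC(O)C(O)Nc1nc(Nc2cccc(-c3ncccn3)c2)c2ncn(C(C)C)c2n1`: "not determined" (no result reported)

Among the compounds with values here, compound 1 is the only member of this small set with a number behind it. Within the data shown here, in an assay on isolated protein (Asteroidea) for inhibition of G2/mitotic-specific cyclin-B (Asterina pectinifera), read by scintillation counting and 33P incorporation, with a stated time of 30 min (on this read-out higher numbers stand for weaker inhibition and lower numbers for stronger inhibition), compound 1 gives 730 nM, and compound 2 and compound 3, which share the same core but carry different side chains, have no reported result, so no comparison between measured compounds is possible here.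

Compound 4, `CCC[C@H](O)Nc1nc(Nc2cccc(-c3cncnc3)c2)c2ncn(C(C)C)c2n1`, has not yet been measured. It differs from compound 1 in a single spot: pyrimidin-5-yl in place of pyrimidin-2-yl on an aromatic carbon. The same six atoms stay, but the ring is attached through a different carbon, so the two nitrogens sit differently relative to the rest of the molecule. Among the measured compounds shown here, with no measured pair that changes this ring, there is no basis for a confident direction. A moderate shift is expected, more likely toward weaker inhibition than toward stronger, but a result within the scatter of compound 1 would not be surprising. For compound 4 the estimate in this assay is 1200 nM, with a plausible range from 300 nM to 5000 nM. That estimate means a step of a 1.6-fold higher number from compound 1 to compound 4 (0.22 log units; within the scatter), expected rather than known.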

Compound 4, half-maximal inhibitory concentration: 300 nM
Beside the measured number, compound 4's estimate is 4.0-fold (0.60 log units) above it; the measured number falls inside the stated range.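

Within the data shown here, changing how the pyrimidine ring is attached is the first change here that can be read against a number: in this assay putting pyrimidin-5-yl in place of pyrimidin-2-yl gives a 2.4-fold lower number from compound 1 to compound 4 (0.39 log units; beyond the scatter) and counts as a modest step beyond the usual scatter. This position therefore responds to the attachment of the ring alone, even though the same atoms stay and the counts of hydrogen-bond donors and acceptors do not change. Nothing available here explains the shift, so its cause remains unknown.

The compounds shown leave open whether a plain phenyl ring, a pyridine ring or an amine at this spot would give a lower or a higher number. They also leave open whether the same step would appear with a longer chain on the shared core.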